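Trading a ring methyl for hydrogen in compound 1

A few compounds are considered here, and "the series" means these few. Any claim that something is new, unique, unknown or untested is made for them only; others in the source may bear on it.

Measured so far in a functional assay on HCT-116 cells (Homo sapiens) for antiproliferative activity, read by MTT assay, with a stated time of 72 h (on this read-out higher numbers stand for weaker inhibition and lower numbers for stronger inhibition), are three compounds:
Compound 1 `CO[C@@H]1C/C=C(\C)C(=O)N(C)[C@@H](C(C)C)C(=O)N[C@H](Cc2ccccc2)C(=O)N[C@@H](C(C)C)C(=O)O[C@H](c2ccccc2)[C@H](C)/C=C/C=C/1C` gives > 100 nM as a limit
Compound 2 `CO[C@@H]1C/C=C(\C)C(=O)N(C)[C@@H](C(C)C)C(=O)N[C@H](Cc2cc(Cl)c(O)c(Cl)c2)C(=O)N[C@@H](C(C)C)C(=O)O[C@H](c2ccccc2)[C@H](C)/C=C/C=C/1C` gives 42.1 nM as a number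
Compound 3 `CC[C@H](C)[C@@H]1NC(=O)[C@]2(C)O[C@H]2C[C@@H](OC)/C(C)=C/C=C/[C@@H](C)[C@@H](c2ccccc2)OC(=O)[C@H](C(C)(C)O)NC(=O)[C@@H](Cc2cc(Cl)c(O)c(Cl)c2)NC1=O` gives > 1000 nM as a limit

Compound 1 has no number in this assay and holds only the limit > 100 nM in this series. Compound 4 `CO[C@@H]1C/C=C(\C)C(=O)N(C)[C@@H](C(C)C)C(=O)N[C@H](Cc2ccccc2)C(=O)N[C@@H](C(C)C)C(=O)O[C@H](c2ccccc2)C/C=C/C=C/1C` departs from compound 1 in one place, counted as hydrogen in place of methyl on a saturated ring carbon and described as hydrogen in place of methyl on a saturated ring carbon, next to the ring atom that bears a phenyl group.

For the measured compounds named here, the only measured step is an at least 2.3-fold lower number from compound 1 to compound 2 (0.37 log units; beyond the scatter) and it comes with 3,5-dichloro-4-hydroxyphenyl in place of phenyl on a saturated chain carbon. That step lies at a different place, so its size cannot be carried over to the methyl. Going by the values given here, compound 3 differs from compound 1 in more than one place and offers no step. No step beyond the scatter is therefore expected in this assay in either direction, and compound 4 is expected to stay close to compound 1 with its limit > 100 nM in that assay.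

The expected change is a step that the limit leaves unreadable from compound 1 to compound 4 as an estimate. In this assay the estimate for compound 4 is 250 nM with an expected range from 100 nM to 1000 nM.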

Compound 4, half-maximal inhibitory concentration: > 100 nM
Compound 4: only a limit was reported; the forecaster's own chance of this, stated with the estimate: 60%; the middle value is on the limit's open side.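

In this assay compound 4 gives > 100 nM as a limit and not a number. Compound 1 also holds only a limit in this assay, so no step can be read from compound 1 to compound 4. The compounds shown leave open whether hydrogen in place of methyl changes the antiproliferative activity at all.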